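This account rests on a few compounds, and the source may have more. Where it says the series, first, only, none or still open, it means among the compounds named here.

In an in vitro ADME assay on microsomes from liver (Homo sapiens) for pharmacokinetics, read by LC-MS, with a stated time of 10 min, tested at 1 uM (on this read-out higher numbers stand for fast clearance and lower numbers for slow clearance), compound 1 (`CN1C[C@H](C(=O)Nc2ccc(C#N)cc2)[C@@H](c2ccc(/C=C/C(=O)Nc3ccccc3N)cc2)C1`) gives 1 mL/min/kg, compound 2 (`CN1C[C@H](C(=O)Nc2cccc(Cl)c2)[C@@H](c2ccc(/C=C/C(=O)Nc3ccccc3N)cc2)C1`) gives 7 mL/min/kg and compound 3 (`COc1cccc(NC(=O)[C@H]2CN(C)C[C@@H]2c2ccc(/C=C/C(=O)Nc3ccccc3N)cc2)c1`) gives 14 mL/min/kg, which places compound 3 with compound 2 at the upper end of the three numbers. Compound 4 (`CN1C[C@H](C(=O)Nc2ccc(F)c(Cl)c2)[C@@H](c2ccc(/C=C/C(=O)Nc3ccccc3N)cc2)C1`) has 3-chloro-4-fluorophenyl in place of 3-methoxyphenyl on an amide-type nitrogen. The closest evidence is a 2.0-fold higher number from compound 2 to compound 3 (0.30 log units; within the scatter), methoxy in place of chloro, within the scatter. The larger steps, a 7.0-fold higher number from compound 1 to compound 2 (0.85 log units; beyond the scatter) and a 14-fold higher number from compound 1 to compound 3 (1.15 log units; beyond the scatter), both leave 4-cyanophenyl, which compound 4 does not carry. No step beyond the scatter is therefore expected in this assay, with any movement expected toward a lower number. The expected step is a 1.8-fold lower number from compound 3 to compound 4 (0.24 log units; within the scatter). Compound 4 is estimated at 8 mL/min/kg, with an expected range of 3 mL/min/kg to 18 mL/min/kg.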

Compound 4, clearance: 15 mL/min/kg
Compound 4: middle estimate off by 1.9-fold (0.27 log units), on the low side, within the range that was stated.
By their numbers in this assay, from the lowest: compound 1; then compounds 2, 3 and 4 (each within the scatter of the next, the first and the last beyond it).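

In this assay, 3-chloro-4-fluorophenyl in place of 3-methoxyphenyl on the amide-type nitrogen gives a 1.1-fold higher number from compound 3 to compound 4 (0.03 log units; within the scatter), so two groups differing in their atoms and hydrogen-bond acceptors are not told apart here. Fluoro in place of hydrogen gives a 2.1-fold higher number from compound 2 to compound 4 (0.33 log units; beyond the scatter), a modest step beyond the scatter, while a 15-fold higher number from compound 1 to compound 4 (1.18 log units; beyond the scatter) leaves 4-cyanophenyl as the only group here with a low number. No measurement at hand accounts for these differences. On these data alone, whether the low number follows the nitrile itself or its place on the ring stays open, as does how an amine or a carboxylic acid on this phenyl would read in this assay.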